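Propyl to butyl on the ether chain: compounds 1 to 3

The source may report more compounds than this note shows. Statements on the series, on what has been measured and on what is new or still open speak of the compounds shown alone.

Measured in a functional assay on HCT-8 cells (Homo sapiens) for cytotoxicity; a higher number here means that more compound is needed for the effect, a lower number that less compound is needed:
- compound 1 `CC(C)Oc1cc(-c2ccccc2)nc2ccccc12`: 10 ug/mL
- compound 2 `CCCOc1cc(-c2ccccc2)nc2ccccc12`: > 10 ug/mL (a limit)

Compound 2 stands only at a limit, > 10 ug/mL, and has no number of its own. Compound 3 `CCCCOc1cc(-c2ccccc2)nc2ccccc12` differs from it by methyl in place of hydrogen on a saturated chain carbon, three bonds along the chain from an oxygen on an aromatic ring, which reads as propyl to butyl. Among the measured compounds shown here, the one measured step that bears on this is a number no lower from compound 1 to compound 2 (the limit leaves the size open), and its size remains open. No drop in the number is therefore expected in this assay, and the expected step is a step that the limit leaves unreadable from compound 2 to compound 3. Compound 3 is estimated at 14 ug/mL, with an expected range of 7 ug/mL to 40 ug/mL.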

Compound 3, half-maximal effective concentration: > 10 ug/mL
Compound 3: no number, only a limit; the forecaster's own chance of this, stated with the estimate: 75%; the middle value is on the limit's open side.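

In this assay compound 3 gives > 10 ug/mL, a limit and not a number. Butyl on the oxygen reads as a number no lower from compound 1 to compound 3 (the limit leaves the size open), the same direction as propyl gave, so neither straight chain has yet brought the number under that of compound 1. The step propyl to butyl cannot be read, and the added methyl has no size here: the limit of > 10 ug/mL in this assay, at which 2 of the 3 values shown sit.

As far as these compounds go, the actual values of compound 2 and compound 3 stay open. Also open, from the compounds shown here alone, is whether an amine on the butyl chain or a longer chain would give a readable number in this assay.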